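The source may hold more compounds than are shown below. What is called first, only, known or untested is meant among the compounds shown, and "the series" means these compounds.

Compound 1, with the structure `CC(/C=N/Nc1ccc([N+](=O)[O-])cc1)=N\NC(=O)c1ccccc1O`, is examined in an ADME assay on J774 cells (Mus musculus, strain BALB/c) for cytotoxicity, read by resazurin assay, with a stated time of 72 h (on this read-out lower numbers stand for higher toxicity in this test and higher numbers for lower toxicity in this test), where compound 1 gives 29500 nM. Among the compounds of this small set that yield an actual number, compound 1 stands at the lowest point, with compound 3 as its nearest neighbour: compound 3, built as `CC(/C=N/Nc1ccc([N+](=O)[O-])cc1)=N\NC(=O)c1ccccc1N`, gives 29800 nM, and the step of a 1.0-fold higher number from compound 1 to compound 3 (0.00 log units; within the scatter) shows that the two sit side by side within the usual scatter. Compound 2, with the structure `CC(/C=N/Nc1ccc([N+](=O)[O-])cc1)=N\NC(=O)c1ccccc1C`, is reported only as a limit of this assay, > 100000 nM, which corresponds to the limit of > 100000 nM in this assay, at which 1 of the 3 values shown sits. Going from compound 1 to compound 2 gives an at least 3.3-fold higher number from compound 1 to compound 2 (0.53 log units; beyond the scatter), and from compound 2 to compound 3 gives an at least 3.3-fold lower number from compound 2 to compound 3 (0.52 log units; beyond the scatter).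

The compound still to be measured, compound 4, has the structure `CC(/C=N/N(C)c1ccc([N+](=O)[O-])cc1)=N\NC(=O)c1ccccc1O`. It differs from compound 1 by methyl in place of hydrogen on a nitrogen on an aromatic ring. For the measured compounds named here, none of the measured steps touches that nitrogen; all three exchange the group on the aromatic carbon of the other ring, so they offer no direct guide to this change. With nothing in the measured steps pointing either way, the expectation for compound 4 is a number close to that of compound 1, the expected step being a 1.2-fold higher number from compound 1 to compound 4 (0.07 log units; within the scatter). Compound 4 is therefore estimated at 35000 nM, most likely between 12000 nM and 100000 nM.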

Compound 4, half-maximal cytotoxic concentration: 31500 nM
Estimate against measurement, compound 4: 1.1-fold (0.05 log units) above; measured number inside the range.
By their numbers in this assay, from the lowest: compounds 1, 3 and 4 (each within the scatter of the next). At a limit, above all of these: compound 2.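

For the compounds shown here, the earlier steps all exchanged a group on an aromatic carbon, so this is the first view of a different place: a nitrogen on an aromatic ring whose other neighbours are an aromatic carbon and a double-bonded nitrogen. In this assay, methyl in place of hydrogen at that nitrogen gives a 1.1-fold higher number from compound 1 to compound 4 (0.03 log units; within the scatter), so the hydrogen there can be replaced by methyl with no shift beyond the scatter in this read-out, whereas the change on the aromatic carbon gives an at least 3.3-fold higher number from compound 1 to compound 2 (0.53 log units; beyond the scatter), a step that does go beyond it. No measurement shown here bears on the reason for this outcome.

Methyl is the only group shown on this nitrogen, so it remains open whether a longer chain such as ethyl, or an acetyl group, would leave the read-out just as undisturbed. Also open, as far as these compounds go, is whether methyl on this nitrogen would behave the same way in a compound carrying amino or methyl instead of hydroxy on the aromatic carbon, since only the hydroxy compounds show this change.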